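The source may hold more compounds than are shown below. What is called first, only, known or untested is meant among the compounds shown, and "the series" means these compounds.

Working notes on the series. Among the measured compounds shown here, compound 1 `COc1ccccc1-n1cc(CN2C(=O)C[C@@H]3CC[C@@]2(C)C3(C)C)nn1` gives 70 nM in a functional assay on LoVo cells (Homo sapiens) for inhibition, read by MTT assay, with a stated time of 24 h (on this read-out lower numbers stand for stronger inhibition and higher numbers for weaker inhibition), the highest of the three numbers measured so far. Compound 2 `CC1(C)[C@H]2CC[C@]1(C)N(Cc1cn(-c3ccccc3Br)nn1)C(=O)C2` gives 60 nM in this assay and compound 3 `CC1(C)[C@H]2CC[C@]1(C)N(Cc1cn(-c3ccc(F)cc3)nn1)C(=O)C2` gives 40 nM. The step of a 1.2-fold lower number from compound 1 to compound 2 (0.07 log units; within the scatter) and the step of a 1.8-fold lower number from compound 1 to compound 3 (0.24 log units; within the scatter) both lie within the scatter, as does the step of a 1.5-fold lower number from compound 2 to compound 3 (0.18 log units; within the scatter), so the three numbers cannot be ordered.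

Compound 4 `CC1(C)[C@H]2CC[C@]1(C)N(Cc1cn(-c3cccc(O)c3)nn1)C(=O)C2` is not yet measured. It differs from compound 1 by 3-hydroxyphenyl in place of 2-methoxyphenyl on an aromatic nitrogen. The measured steps that bear on it are those in which the aryl group on the same aromatic nitrogen was exchanged, a 1.2-fold lower number from compound 1 to compound 2 (0.07 log units; within the scatter) and a 1.8-fold lower number from compound 1 to compound 3 (0.24 log units; within the scatter), each within the scatter. For the measured compounds named here, no measured compound carries a hydroxyl, so nothing shows how that group reads in this assay. On the steps seen, no change beyond the scatter is expected. The expected step is a 1.2-fold lower number from compound 1 to compound 4 (0.07 log units; within the scatter). Compound 4 is estimated at 60 nM in this assay, with a range from 25 nM to 150 nM.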

Compound 4, half-maximal inhibitory concentration: 410 nM
For compound 4 the middle estimate is 6.8-fold (0.83 log units) below the measured one; the measured number lies above the stated range.
By their numbers in this assay, from the lowest: compounds 3, 2 and 1 (each within the scatter of the next); then compound 4.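

The aryl group on the aromatic nitrogen is less tolerant of change than compounds 1 to 3 suggested. In this assay the step of a 5.9-fold higher number from compound 1 to compound 4 (0.77 log units; beyond the scatter), the step of a 6.8-fold higher number from compound 2 to compound 4 (0.83 log units; beyond the scatter) and the step of a 10-fold higher number from compound 3 to compound 4 (1.01 log units; beyond the scatter) all lie beyond the scatter, whereas exchanges among 2-methoxyphenyl, 2-bromophenyl and 4-fluorophenyl stayed within it. Compound 4 alone carries a hydrogen-bond donor, but its change from compound 1 also replaces the 2-methoxyphenyl pattern with a 3-hydroxyphenyl pattern, and no evidence at hand accounts for the weaker reading.

From the compounds shown here alone, whether the hydroxyl itself or its place on the ring drives the step stays open, and 3-methoxyphenyl on the same nitrogen would separate the two. A 3-aminophenyl group would show whether an amine reads like the hydroxyl.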